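From Cyclopentylamino to Cyclohexylamino on a Shared Core

A few compounds are considered here, and "the series" means these few. Any claim that something is new, unique, unknown or untested is made for them only; others in the source may bear on it.

Of the compounds shown here, three on a shared core have been measured in a functional assay on HeLa cells (Homo sapiens) for inhibition, read by sulforhodamine B assay; a lower number here means a stronger inhibitor, a higher number a weaker inhibitor. Compound 1 `CCCc1ccc(NC2=CC(=O)c3nc4n(c3C2=O)[C@H]2OC[C@@H](O)[C@H]2OC4)cc1` gives 4990 nM in this assay. For the measured compounds named here, compound 3 `O=C1C=C(Nc2cccc(F)c2)C(=O)c2c1nc1n2[C@H]2OC[C@@H](O)[C@H]2OC1` gives 6440 nM in this assay, and the change a 1.3-fold higher number from compound 1 to compound 3 (0.11 log units; within the scatter) is the only step between measured compounds that differ in one place. Compound 2 `O=C1C(NC2CCCC2)=CC(=O)c2c1nc1n2[C@H]2OC[C@@H](O)[C@H]2OC1` returns only a limit in this assay, > 16000 nM, and it sits at the limit of > 16000 nM in this assay, at which 1 of the 3 values shown sits. Compound 4 `O=C1C(NC2CCCCC2)=CC(=O)c2c1nc1n2[C@H]2OC[C@@H](O)[C@H]2OC1` has not yet been measured, and it differs from compound 2 by cyclohexyl in place of cyclopentyl on an amine nitrogen. Going by the values given here, no measured step bears on this change: the one step known, from compound 1 to compound 3, puts 3-fluorophenyl in place of 4-propylphenyl and stays within the scatter, and it says nothing about the exchange of cyclopentyl for cyclohexyl. Among the compounds with values here, because compound 2 stands at the limit of > 16000 nM in this assay, at which 1 of the 3 values shown sits, no step down can be read from its value either. Compound 4 is therefore expected to remain near that limit, with the step of a number no higher from compound 2 to compound 4 (the limit leaves the size open) carrying little weight. The estimate for compound 4 in this assay is 16000 nM, with a range from 8000 nM to 40000 nM.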

Compound 4, half-maximal inhibitory concentration: > 16000 nM
Compound 4: a limit, no number; the forecaster's own chance of this, stated with the estimate: 60%; the middle value sits exactly at the limit.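

In this assay compound 4 returns only a limit, > 16000 nM. Compound 2 also returns only a limit, and no step can be read between compound 2 and compound 4: the limit of > 16000 nM in this assay, at which 2 of the 4 values shown sit.

The compounds shown leave open what the actual values of compound 2 and compound 4 are, and whether cyclohexyl and cyclopentyl on an amine nitrogen differ at all.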